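The compounds below may be only part of what the source reports. "The series", "measured", "known", "first", "only" and "open" are said of these compounds alone.

Of the compounds shown here, three built on a shared core have been tested in a functional assay on the whole organism (strain albino) for inhibition, with Rattus norvegicus as the target, read by paw edema, with stated times of 30 min and 4 h, at a dose of 0.28 mmol/kg by the oral route; a higher number here means more inhibition at the dose given (going by the name of the read-out), a lower number less inhibition. Compound 1 `COc1ccc(-c2nnc(SCC(=O)Nc3ccc(/C(C)=N/O)cc3)n2-c2ccccc2)cc1` gives 69% in this assay. Compound 2 `CCn1c(SCC(=O)Nc2ccc(C(C)=O)cc2)nnc1-c1ccc(OC)cc1` gives 65%, and compound 3 `C=CCn1c(SCC(=O)Nc2ccc(C(C)=O)cc2)nnc1-c1ccc(OC)cc1` gives 68%. On the bare numbers compound 3 stands second of the three, but its gaps to compound 1 and to compound 2 are both within the scatter, so these three values cannot be told apart with confidence.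

Compound 4 `COc1ccc(-c2nnc(SCC(=O)Nc3ccc(C(C)=O)cc3)n2-c2ccccc2)cc1` has not yet been measured. It differs from compound 3 in one place: phenyl in place of allyl on an aromatic nitrogen. Among the compounds with values here, the only measured step at that same nitrogen is a number 3 percentage points higher from compound 2 to compound 3 (within the scatter), a swap of one small chain for another that left the number essentially where it was. Compound 1 also carries a phenyl on this nitrogen, and its value in this assay lies within the scatter of the value of compound 3, although compound 1 differs from compound 3 in a second place as well. Nothing measured therefore points to a step beyond the scatter in this assay, in either direction. The step expected from compound 3 to compound 4 is a number 1 percentage points lower from compound 3 to compound 4 (within the scatter). Compound 4 is estimated to give 67%, with a range from 57% to 77%.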

Compound 4, a percentage reported as inhibition, in the whole organism at one dose (the size of the read-out at that dose, not a potency): 63%
Compound 4: middle estimate off by 4 percentage points, on the high side, and the stated range covers the measured number.
By their numbers in this assay, from the lowest: compounds 4, 2, 3 and 1 (each within the scatter of the next).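

In this assay, the aromatic nitrogen accepts a phenyl ring as readily as a small chain: phenyl in place of allyl gives (a number 5 percentage points lower from compound 3 to compound 4 (within the scatter)), and phenyl in place of ethyl gives (a number 2 percentage points lower from compound 2 to compound 4 (within the scatter)). With phenyl held on that nitrogen, a second place can also be read, and a group of 3 heavy atoms in place of a group of 4 heavy atoms on an aromatic carbon gives (a number 6 percentage points lower from compound 1 to compound 4 (within the scatter)). Thus a ring of 6 heavy atoms on this nitrogen, where the earlier step compared only two small chains, still produces no change that can be told from the scatter, and neither does the swap on the aromatic carbon.

On these data alone, whether a longer chain, or a chain ending in an amine or a carboxylic acid, on this nitrogen would move the number beyond the scatter remains open, since all four compounds give values that cannot be separated with confidence. Nothing available bears on why the values of these compounds lie so close together.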